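Swapping a Piperidine for a Piperazine Amide

The source may report more compounds than this note shows. Statements on the series, on what has been measured and on what is new or still open speak of the compounds shown alone.

Three compounds have been measured in a functional assay on CAL-51 cells (Homo sapiens) for antiproliferative activity, read by luminescence and CellTiter-Glo, with a stated time of 3 days; a lower number here means a stronger inhibitor, a higher number a weaker inhibitor:
compound 1 `CCOc1cc(C(=O)N(C)C)ccc1Nc1nc(O[C@H]2CC[C@@](C)(O)CC2)c2cc[nH]c2n1` gives 26 nM
compound 2 `COc1cc(N2CCC(C)(O)CC2)ccc1Nc1nc(O[C@H]2CCOC(C)(C)C2)c2cc[nH]c2n1` gives 71 nM
compound 3 `COc1cc(C(=O)N(C)C)ccc1Nc1nc(OC2CCCCC2)c2cc[nH]c2n1` gives 190 nM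

Compound 2 sits in the middle of these three numbers, with a gap to compound 1 and a gap to compound 3 that both lie beyond the scatter. The new compound 4 `COc1cc(N2CCN(C(=O)CO)CC2)ccc1Nc1nc(O[C@H]2CCOC(C)(C)C2)c2cc[nH]c2n1` is built from compound 2 by one change (4-((hydroxymethyl)carbonyl)piperazin-1-yl in place of 4-hydroxy-4-methylpiperidin-1-yl on an aromatic carbon). Among the compounds with values here, no measured pair shows this kind of exchange, so there is no reference step to lean on. Both groups are ring substituents of similar size, and a step in this assay of no more than the scatter is expected, in either direction. Compound 4 is therefore expected to give about 80 nM, within 30 nM to 220 nM, a change of a 1.1-fold higher number from compound 2 to compound 4 (0.05 log units; within the scatter).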

Compound 4, half-maximal inhibitory concentration: 37 nM
Compound 4: the middle estimate sits 2.2-fold (0.33 log units) above what was measured; measured number inside the range.
By their numbers in this assay, from the lowest: compounds 1, 4 and 2 (each within the scatter of the next, the first and the last beyond it); then compound 3.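

At this place on the aromatic ring, para to a large group, the 4-((hydroxymethyl)carbonyl)piperazin-1-yl group can stand in for 4-hydroxy-4-methylpiperidin-1-yl. In this assay, the exchange gives a 1.9-fold lower number from compound 2 to compound 4 (0.28 log units; within the scatter). The larger group, with its second ring nitrogen and its carbonyl, therefore leaves the antiproliferative reading within the scatter, though nothing available explains this result.

The compounds shown leave open what the hydroxyl end of the new group contributes, which a plain acetyl on the piperazine could separate from the ring itself. A morpholine at this place also remains an open comparison.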